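Methyl on the ring nitrogen of a weak antiproliferative scaffold

The source may report more compounds than this note shows. Statements on the series, on what has been measured and on what is new or still open speak of the compounds shown alone.

In a functional assay on MCF7 cells (Homo sapiens) for antiproliferative activity, read by MTT assay, with a stated time of 72 h (on this read-out higher numbers stand for weaker inhibition and lower numbers for stronger inhibition), compound 2 `CC1Oc2ccc(Br)cc2C=C1/C=C1\SC(=O)NC1=O` gives 67600 nM, the second highest of three numbers. Compound 1 `O=C1NC(=O)/C(=C/C2=Cc3cc(Br)ccc3OC2)S1` gives 57900 nM and compound 3 `CC1Oc2ccc(Br)cc2C=C1/C=C1/C(=O)NC(=N)N1C` gives 84800 nM; both lie within the scatter of compound 2, so none of the three can be called more or less potent than another. Compound 4 `CC1Oc2ccc(Br)cc2C=C1/C=C1\SC(=O)N(C)C1=O` carries methyl in place of hydrogen on an amide-type nitrogen in a ring. Going by the values given here, the only measured step that resembles it, a 1.2-fold higher number from compound 1 to compound 2 (0.07 log units; within the scatter), added a methyl elsewhere and stayed within the scatter. Among the compounds with values here, a methyl placed on the ring nitrogen has no measured precedent here, so the expectation rests on that single step alone. Compound 4 is therefore expected to show a 1.1-fold higher number from compound 2 to compound 4 (0.05 log units; within the scatter), giving an estimated 75000 nM with a range from 30000 nM to 180000 nM.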

Compound 4, half-maximal inhibitory concentration: > 50000 nM
Compound 4 gave a limit, no number; the forecaster's own chance of this, stated with the estimate: 15%; the middle value does not contradict the limit.
By their numbers in this assay, from the lowest: compounds 1, 2 and 3 (each within the scatter of the next).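

In this assay, going by these compounds alone, compound 4 gives > 50000 nM, which is a limit and not a number, so no step from compound 2 to compound 4 can be read. The compounds shown leave open whether methyl on the ring nitrogen changes the number at all, and by how much.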